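Replacing 1H-indol-3-yl with 2-chloro-4-fluorophenyl

The source may hold more compounds than are shown below. What is called first, only, known or untested is meant among the compounds shown, and "the series" means these compounds.

In a functional assay on DU-145 cells (Homo sapiens) for inhibition, read by trypan blue exclusion, with a stated time of 96 h (on this read-out higher numbers stand for weaker inhibition of growth and lower numbers for stronger inhibition of growth), compound 1 `O=C(/C(=C\c1ccc(F)cc1)S(=O)(=O)c1ccc(Br)cc1)c1ccc(Br)cc1` gives 4000 nM, while compound 2 `O=C(/C(=C\c1c[nH]c2ccccc12)S(=O)(=O)c1ccc(Br)cc1)c1ccc(Br)cc1` gives 25000 nM. Compound 2 therefore has the higher of the two numbers and is the weaker growth inhibitor of the pair. The next structure, compound 3 `O=C(/C(=C\c1ccc(F)cc1Cl)S(=O)(=O)c1ccc(Br)cc1)c1ccc(Br)cc1`, changes one group of compound 2: 2-chloro-4-fluorophenyl in place of 1H-indol-3-yl on a double-bonded chain carbon bound to a double-bonded chain carbon. Here, 2-chloro-4-fluorophenyl takes the place of 1H-indol-3-yl on a double-bonded chain carbon bound to a double-bonded chain carbon.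

Among the measured compounds shown here, only one measured step bears on this change: a 6.3-fold higher number from compound 1 to compound 2 (0.80 log units; beyond the scatter), where 1H-indol-3-yl replaced 4-fluorophenyl at that same place. For the measured compounds named here, the entering group also carries a 4-fluoro substituent, but no measured compound shows what adding the chloro does. A step of similar size toward a lower number is therefore expected, estimated as a 7.1-fold lower number from compound 2 to compound 3 (0.85 log units; beyond the scatter). For compound 3, the expected value is 3500 nM, with an estimated range of 1000 nM to 12000 nM.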

Compound 3, concentration for 50% growth inhibition: 50000 nM
For compound 3 the middle estimate is 14-fold (1.15 log units) below the measured one, and the stated range ends below it.
By their numbers in this assay, from the lowest: compound 1; then compounds 2 and 3 (each within the scatter of the next).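

In this assay, the new result shows that a single added chloro on the aromatic ring matters a great deal here, with a 13-fold higher number from compound 1 to compound 3 (1.10 log units; beyond the scatter), so compound 1 remains the strongest growth inhibitor of the three. The exchange itself gives a 2.0-fold higher number from compound 2 to compound 3 (0.30 log units; within the scatter), so 1H-indol-3-yl, with two rings and a hydrogen-bond donor, and 2-chloro-4-fluorophenyl, with one ring and no donor, cannot be told apart at this place. No measurement available here accounts for either result.

As far as these compounds go, it remains open whether the chloro is specific in this effect, or whether a methyl or methoxy group in its place would give a similar step. From the compounds shown here alone, the effect of removing the fluoro to leave a plain phenyl also remains unknown.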